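The compounds below may be only part of what the source reports. "The series", "measured", "known", "first", "only" and "open" are said of these compounds alone.

Measured compounds in a functional assay on T47D cells (Homo sapiens) for cytotoxicity, read by CCK-8 assay; a higher number here means a weaker inhibitor, a lower number a stronger inhibitor:
- compound 1 `Oc1ccccc1-c1cc(-c2cccs2)cc(-c2ccccc2O)n1` gives > 50000 nM, a limit of this assay rather than a number.
- compound 2 `Oc1ccccc1-c1cc(-c2ccsc2)cc(-c2ccccc2O)n1` gives > 50000 nM, again only a limit of this assay.
- compound 3 `Oc1ccc(-c2cc(-c3ccsc3)cc(-c3ccccc3O)n2)cc1` gives > 50000 nM, likewise a limit of this assay.

Compound 2 therefore stands nowhere in particular on the numbers shown: its value in this assay is a limit, and the two other values shown are limits as well, so no ordering among compounds 1, 2 and 3 can be read. The two measured steps that touch compound 2 are a step that the two limits leave unreadable from compound 1 to compound 2 and a step that the two limits leave unreadable from compound 2 to compound 3; neither is readable in size or direction because of the limit of > 50000 nM in this assay, at which 3 of the 3 values shown sit.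

The unmeasured compound 4 `Oc1ccccc1-c1cc(-c2ccco2)cc(-c2ccccc2O)n1` differs from compound 2 by furan-2-yl in place of thiophen-3-yl on an aromatic carbon. Among the compounds with values here, the change is of the same kind as the measured exchange of one five-membered ring for another, and the steps that bear on it give no size at all. No step beyond the scatter can be predicted in this assay, and the most likely outcome is a further limit. Compound 4 is expected to give about 50000 nM, with a range from 20000 nM to 150000 nM, most probably reported only as a limit. The expected step from compound 2 to compound 4 is estimated as a number no higher from compound 2 to compound 4 (the limit leaves the size open), which is to say no readable change.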

Compound 4, half-maximal inhibitory concentration: > 50000 nM
Compound 4: a limit, no number; the forecaster's own chance of this, stated with the estimate: 85%; the middle value sits exactly at the limit.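

In this assay compound 4 gives > 50000 nM, a limit and not a number. No new step can be read from compound 1 or compound 2 to compound 4 because all the values share one limit: the limit of > 50000 nM in this assay, at which 4 of the 4 values shown sit.

The compounds shown leave open which change to the shared core, if any, would yield a measurable value.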